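The compounds below may be only part of what the source reports. "The series", "measured", "known", "first", "only" and "open" are said of these compounds alone.

Measured so far:
Compound 1 `COc1ccc(-c2cc(=O)c3c(O)c(OC)c(O[C@@H]4O[C@H](CO[C@@H]5O[C@@H](C)[C@H](O)[C@@H](OC(C)=O)[C@H]5O)[C@@H](O)[C@H](O)[C@H]4O)cc3o2)cc1`: 28400 nM
Compound 2 `COC1=C(O)C2=C(O)C=C(c3ccc(OC)cc3)OC2=CC1OC1OC(O)C(O)C(O)C1O`: 6900 nM

Of the compounds shown here, two have been measured in a functional assay on COR-L23 cells (Homo sapiens) for inhibition, in the presence of a further agent that is not named here; a higher number here means a weaker inhibitor, a lower number a stronger inhibitor. Compound 1 gives 28400 nM, and compound 2 gives 6900 nM. Of these two numbers compound 1 has the higher one, so it is the weaker inhibitor of the pair, and the gap to compound 2 lies beyond the scatter, so that order can be trusted. Among the measured compounds shown here, no step between measured compounds that differ in a single place is available, so nothing has yet been learned about what any particular change does here.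

Compound 3 `COc1ccc(-c2cc(=O)c3c(O)c(OC)c(O[C@@H]4OC(CO[C@@H]5OC(C)[C@H](O)[C@H](OC(C)=O)C5O)[C@@H](O)[C@H](O)C4O)cc3o2)cc1` is not yet measured. Set against compound 1 it keeps every atom and every bond; the difference lies only in how the stereochemistry is drawn: the two compounds have the same atoms and bonds; at least one stereo element is drawn with a configuration in one of them and without one in the other: 5 of 10 stereo elements differ; a stereocentre at a saturated ring carbon is drawn R in compound 1 and without a configuration in compound 3; a stereocentre at a saturated ring carbon is drawn S in compound 1 and without a configuration in compound 3; a stereocentre at a saturated ring carbon is drawn R in compound 1 and S in compound 3; a stereocentre at a saturated ring carbon is drawn R in compound 1 and without a configuration in compound 3. For the measured compounds named here, with the connectivity unchanged and no measured pair to show what a change of this kind does, the expectation is a step within the scatter, in no particular direction. The step this estimate means, a 1.0-fold lower number from compound 1 to compound 3 (0.01 log units; within the scatter), is expected to be of no real size. For compound 3 the estimated value in this assay is 28000 nM, with a range from 10000 nM to 80000 nM.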

Compound 3, half-maximal inhibitory concentration: 10400 nM
The estimate for compound 3 lay 2.7-fold (0.43 log units) above the measured number, within the range that was stated.
By their numbers in this assay, from the lowest: compounds 2 and 3 (each within the scatter of the next); then compound 1.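

Until now, no pair of compounds had shown what stereochemistry alone does in this assay. With every atom and bond kept, the change in how the saturated ring carbons are drawn goes with a 2.7-fold lower number from compound 1 to compound 3 (0.44 log units; beyond the scatter), so the read-out at these centres is not indifferent to how their configuration is defined, even though the step is modest. Because several stereo elements differ at once, with one centre going from R to S and others losing their drawn configuration, the step belongs to the whole set of centres and to no single one, and the firmest basis for reading it is this: the fact that one of compounds 1 and 3 is drawn with a defined configuration and the other without, at the place where they differ.

The compounds shown leave open which stereocentre matters, and whether a single fully defined isomer with the configuration changed at just one centre would give a step of similar size. They also leave open how the read-out would respond to a change of group rather than of drawing, such as an amine or a carboxylic acid in place of the acetate ester.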